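Aryl swap on the triazole nitrogen, compound 3 to compound 4

A few compounds are considered here, and "the series" means these few. Any claim that something is new, unique, unknown or untested is made for them only; others in the source may bear on it.

Compound 1 `CCOc1ccccc1-n1nncc1CN1C(=O)C2(C(C#N)=C(N)Oc3c2c2nc4ccccc4nc2c2ccccc32)c2ccccc21` is measured in a functional assay on A549 cells (Homo sapiens) for antiproliferative activity, read by MTT assay, with a stated time of 48 h (on this read-out lower numbers stand for stronger inhibition and higher numbers for weaker inhibition), and gives only a limit, > 50000 nM. Compound 2 `Cc1cc(C)cc(-n2nncc2CN2C(=O)C3(C(C#N)=C(N)Oc4c3c3nc5ccccc5nc3c3ccccc43)c3ccccc32)c1` likewise gives only a limit in this assay, > 50000 nM. The step that the two limits leave unreadable from compound 1 to compound 2 is therefore not readable, as noted in the limit of > 50000 nM in this assay, at which 2 of the 3 values shown sit. Going by the values given here, compound 3 `N#CC1=C(N)Oc2c(N)cc3nc4ccccc4nc3c2C12C(=O)N(Cc1cnnn1-c1ccccc1Br)c1ccccc12` is the one member with a number: in this assay compound 3 gives 27400 nM, the only numeric value in the set.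

Compound 4 `N#CC1=C(N)Oc2c(N)cc3nc4ccccc4nc3c2C12C(=O)N(Cc1cnnn1-c1ccc(F)c(Cl)c1)c1ccccc12` differs from compound 3 only by 3-chloro-4-fluorophenyl in place of 2-bromophenyl on an aromatic nitrogen. No measured step touches this kind of change: the one step shown, from compound 1 to compound 2, is unreadable and concerns a different pair of aryl groups. There is thus no basis for expecting a shift beyond the scatter in this assay in either direction. Compound 4 is estimated at 30000 nM, within 12000 nM to 75000 nM, an expected step of a 1.1-fold higher number from compound 3 to compound 4 (0.04 log units; within the scatter), with a real chance that only a limit is reported.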

Compound 4, half-maximal inhibitory concentration: 43400 nM
Compound 4: the middle estimate sits 1.4-fold (0.16 log units) below what was measured; measured number inside the range.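

Going by these compounds alone, the pair gives the first readable step on this aromatic nitrogen in this assay: a 1.6-fold higher number from compound 3 to compound 4 (0.20 log units; within the scatter). The exchange of 2-bromophenyl for 3-chloro-4-fluorophenyl therefore leaves the two compounds within the scatter of each other, and this change does not separate them. Compound 1 and compound 2 give only limits, their step cannot be read, and the limit remains common in the set: the limit of > 50000 nM in this assay, at which 2 of the 4 values shown sit.

Still open, on these data alone, is whether an aryl group carrying an amine or a carboxylic acid, or a saturated alkyl chain in place of the aryl group, would give a step beyond the scatter on this nitrogen. Equally open, as far as these compounds go, is what a change elsewhere on the core shared by compound 3 and compound 4 would do in this assay.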